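Permeability notes: primary amine replaced by piperidinylethyl

The compounds below may be only part of what the source reports. "The series", "measured", "known", "first", "only" and "open" are said of these compounds alone.

Measured so far:
compound 1 `NC/C=C/CN(C[C@H]1Cc2ncccc2CN1)[C@H]1CCCc2cccnc21`: 15 nm/s
compound 2 `NC(=O)NCCCCN(C[C@H]1Cc2ncccc2CN1)[C@H]1CCCc2cccnc21`: 2 nm/s
compound 3 `NC(=O)NC/C=C\CN(C[C@H]1Cc2ncccc2CN1)[C@H]1CCCc2cccnc21`: 2 nm/s

In an ADME assay for permeability, using PAMPA, with a stated time of 4 h, at pH 7.4 (a lower number here means that the compound crosses the layer more slowly, a higher number that the compound crosses the layer faster), compound 1 gives the highest of the three numbers. The two measured steps both leave compound 1: a 7.5-fold lower number from compound 1 to compound 2 (0.88 log units; beyond the scatter) and a 7.5-fold lower number from compound 1 to compound 3 (0.88 log units; beyond the scatter). Between compound 2 and compound 3 there is no change at the digits printed from compound 2 to compound 3 (within the scatter).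

Compound 4 `c1cnc2c(c1)CN[C@@H](CN(CCCC1CCNCC1)[C@H]1CCCc3cccnc31)C2` is not yet measured. The change from compound 1 is 2-(piperidin-4-yl)ethyl in place of 3-aminoprop-1-en-1-yl on a saturated chain carbon bound to an amine nitrogen. Neither measured step bears on it directly: both steps from compound 1 bring in a group of 7 heavy atoms with an oxygen and two nitrogens and lose the number modestly, whereas the entering group here carries one hydrogen-bond donor and one hydrogen-bond acceptor, the same counts as the leaving group, with no oxygen. Without a matching step, no change beyond the scatter is expected from compound 1 to compound 4, that is no change at the digits printed from compound 1 to compound 4 (within the scatter). Compound 4 is therefore estimated at 15 nm/s, with a range from 5 nm/s to 40 nm/s.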

Compound 4, apparent permeability: 24 nm/s
Compound 4: middle estimate off by 1.6-fold (0.20 log units), on the low side, and the stated range covers the measured number.
By their numbers in this assay, from the lowest: compounds 2 and 3 (each within the scatter of the next); then compounds 1 and 4 (each within the scatter of the next).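

In this assay, the place on a saturated chain carbon bound to an amine nitrogen accepts a saturated ring: 2-(piperidin-4-yl)ethyl and 3-aminoprop-1-en-1-yl cannot be told apart (a 1.6-fold higher number from compound 1 to compound 4 (0.20 log units; within the scatter)). Heavy atom count does not track the numbers among these four compounds, since compound 4 carries the largest entering group yet sits well clear of both ureido compounds (a 12-fold higher number from compound 3 to compound 4 (1.08 log units; beyond the scatter); a 12-fold higher number from compound 2 to compound 4 (1.08 log units; beyond the scatter)), so the low numbers so far go with the ureido compounds, compound 2 and compound 3. Nothing available here accounts for these differences.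

Still open, as far as these compounds go, is whether the ring nitrogen matters, which a 2-cyclohexylethyl group at this place would test. An acetamide or a carboxylic acid at the chain end would show whether the low numbers are specific to the urea.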